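Indazole to Benzotriazole: Expected Clearance for Compound 4

The source may report more compounds than this note shows. Statements on the series, on what has been measured and on what is new or still open speak of the compounds shown alone.

Compound 1, `COc1cc(N2CCN(C(=O)Cn3ncc4ccccc43)CC2)ccc1-c1cnc(C)o1`: 77 mL.min-1.g-1
Compound 2, `COc1cc(C2CCN(C(=O)N[C@@H](C)c3cccc4ccccc34)CC2)ccc1-c1cnc(C)o1`: 170 mL.min-1.g-1
Compound 3, `COc1cc(N2CCCN(C(=O)N[C@@H](C)c3cccc4ccccc34)CC2)ccc1-c1cnc(C)o1`: 240 mL.min-1.g-1

In an ADME assay on microsomes from liver (Rattus norvegicus) for metabolic stability, read by LC-MS (a lower number here means slower removal, a higher number faster removal of the compound), compound 1 gives 77 mL.min-1.g-1, the lowest of the three numbers. Compound 2 gives 170 mL.min-1.g-1 and compound 3 gives 240 mL.min-1.g-1; both stand above compound 1 by more than the usual scatter, compound 3 the furthest away. For the measured compounds named here, none of these three compounds differs from another in a single place, so no measured step exists to lean on.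

Compound 4, `COc1cc(N2CCN(C(=O)Cn3nnc4ccccc43)CC2)ccc1-c1cnc(C)o1`, is built from compound 1 by one change: a group of 9 heavy atoms (6 carbon, 3 nitrogen; one five-membered aromatic ring with 3 hetero atoms, one six-membered aromatic ring of carbon only) in place of a group of 9 heavy atoms (7 carbon, 2 nitrogen; one five-membered aromatic ring with 2 hetero atoms, one six-membered aromatic ring of carbon only), on a saturated chain carbon bound to a carbonyl carbon. Going by the values given here, no measured pair shows this change. The account expects at most a small move downward from compound 1, or none beyond the scatter. Compound 4 is therefore estimated at 60 mL.min-1.g-1, within a range from 30 mL.min-1.g-1 to 120 mL.min-1.g-1. The expected step of a 1.3-fold lower number from compound 1 to compound 4 (0.11 log units; within the scatter) stays within the scatter.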

Compound 4, intrinsic clearance in microsomes: 27 mL.min-1.g-1
Estimate against measurement, compound 4: 2.2-fold (0.35 log units) above; measured number outside the range, below it.
By their numbers in this assay, from the lowest: compound 4; then compound 1; then compounds 2 and 3 (each within the scatter of the next).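

In this assay this place on a saturated chain carbon bound to a carbonyl carbon proves responsive: with the heavy atom count unchanged, replacing 1H-indazol-1-yl with the group holding 3 nitrogen gives a 2.9-fold lower number from compound 1 to compound 4 (0.46 log units; beyond the scatter) in a step beyond the scatter. Compounds 2 and 3 could not show this, as neither carries either group. No measurement shown bears on why the number falls.

From the compounds shown here alone, whether a plain phenyl or a 1H-imidazol-1-yl group at this place would give a lower or higher number stays open. So does whether the step holds on any other core.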